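Fluoro added to compound 1: expected potency step

A few compounds are considered here, and "the series" means these few. Any claim that something is new, unique, unknown or untested is made for them only; others in the source may bear on it.

Measured in a functional assay on HepG2 cells (Homo sapiens) for antiproliferative activity, read by MTT assay, with a stated time of 72 h; a lower number here means a stronger inhibitor, a higher number a weaker inhibitor:
compound 1 `COc1cc(N(C)CCN(C)C)c(NC(=O)/C=C\C(C)C)cc1Nc1ncc(C#N)c(-c2cn(C)c3ccccc23)n1` gives 1810 nM
compound 2 `CCC/C=C\C(=O)Nc1cc(Nc2ncc(C#N)c(-c3cn(C)c4ccccc34)n2)c(OC)cc1N(C)CCN(C)C` gives 1690 nM

Compound 1 holds the higher of the two numbers in this assay, but the step of a 1.1-fold lower number from compound 1 to compound 2 (0.03 log units; within the scatter) lies within the scatter, so the two compounds cannot be told apart. Compound 3 `COc1cc(N(C)CCN(C)C)c(NC(=O)/C=C\C(C)C)cc1Nc1ncc(C#N)c(-c2cn(C)c3ccc(F)cc23)n1` differs from compound 1 by fluoro in place of hydrogen on an aromatic carbon. Among the measured compounds shown here, no measured step touches this change; the only known step, a 1.1-fold lower number from compound 1 to compound 2 (0.03 log units; within the scatter), concerns propyl in place of isopropyl on the chain and does not bear on the 1-methyl-1H-indol-3-yl group. With nothing to go on, the expected step of a 1.0-fold lower number from compound 1 to compound 3 (0.00 log units; within the scatter) is none beyond the scatter. Compound 3 is therefore estimated at 1800 nM, range 600 nM to 5400 nM.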

Compound 3, half-maximal inhibitory concentration: 2840 nM
Compound 3: the middle estimate sits 1.6-fold (0.20 log units) below what was measured; low and high end bracket the measured number.
By their numbers in this assay, from the lowest: compounds 2, 1 and 3 (each within the scatter of the next).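

Fluoro on this aromatic carbon, turning 1-methyl-1H-indol-3-yl into 5-fluoro-1-methyl-1H-indol-3-yl, gives in this assay a 1.6-fold higher number from compound 1 to compound 3 (0.20 log units; within the scatter) and is the first reading on this part of the series. The position accepts one fluorine with no effect that can be told from the scatter. No measurement at hand accounts for this reading.

On these data alone, whether chloro, methoxy or phenyl on the same carbon moves the number beyond the scatter stays open. So does whether fluoro reads the same alongside the propyl chain of compound 2.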